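The compounds below may be only part of what the source reports. "The series", "measured", "known", "first", "only" and "open" are said of these compounds alone.

In a functional assay on MCF7 cells (Homo sapiens) for cytotoxicity, read by MTT assay, with a stated time of 48 h (a higher number here means a weaker inhibitor, a lower number a stronger inhibitor), three compounds with the shared core have been measured. Compound 1 `COc1ccccc1-c1nnc(SCCn2c([N+](=O)[O-])cnc2C)o1` gives 10800 nM and compound 2 `Cc1ncc([N+](=O)[O-])n1CCSc1nnc(-c2ccc(Cl)cc2)o1` gives 18700 nM on the same read-out. Compound 3 `Cc1cccc(-c2nnc(SCCn3c([N+](=O)[O-])cnc3C)o2)c1O` gives 19900 nM and stands level with both, with a 1.1-fold higher number from compound 2 to compound 3 (0.03 log units; within the scatter) as the nearest step and a 1.8-fold higher number from compound 1 to compound 3 (0.27 log units; within the scatter) as the furthest in this set.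

The change to compound 4 `Cc1ncc([N+](=O)[O-])n1CCSc1nnc(-c2ccc(N)nc2)o1` is 6-aminopyridin-3-yl in place of 2-hydroxy-3-methylphenyl on an aromatic carbon and in words is 6-aminopyridin-3-yl in place of 2-hydroxy-3-methylphenyl on an aromatic carbon. All measured swaps at this place bear on it. Besides the two above, a 1.7-fold higher number from compound 1 to compound 2 (0.24 log units; within the scatter) also stayed small. None of them brings in a ring with a hetero atom, so the guidance is indirect. No step beyond the scatter is expected in this assay for this swap. The expected step is a 1.3-fold lower number from compound 3 to compound 4 (0.12 log units; within the scatter) by this estimate. Compound 4 is expected at 15000 nM with an estimated range of 7000 nM to 32000 nM for a single measurement.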

Compound 4, half-maximal inhibitory concentration: 26800 nM
Estimate against measurement, compound 4: 1.8-fold (0.25 log units) below, and the stated range covers the measured number.
By their numbers in this assay, from the lowest: compounds 1, 2, 3 and 4 (each within the scatter of the next, the first and the last beyond it).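

In this assay, 6-aminopyridin-3-yl is the only group shown at this place with a hetero atom in its six-membered aromatic ring, and it stays within the scatter of two of the carbon-only rings (a 1.3-fold higher number from compound 3 to compound 4 (0.13 log units; within the scatter)) and (a 1.4-fold higher number from compound 2 to compound 4 (0.16 log units; within the scatter)). Against 2-methoxyphenyl the same group gives the only step in the set beyond the scatter, a modest one (a 2.5-fold higher number from compound 1 to compound 4 (0.39 log units; beyond the scatter)), so this position can register a difference, though only between the two ends of a closely spaced series. No measured evidence on the origin of these steps is at hand.

Still open, going by these compounds, is whether the ring nitrogen or the amine matters more, which the same ring without its amine would separate. Also open, on these data alone, is how a carboxylic acid or a longer alkyl chain at this place would read out.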